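This account rests on a few compounds, and the source may have more. Where it says the series, first, only, none or still open, it means among the compounds named here.

Measured in an ADME assay on MRC5 cells (Homo sapiens), read by MTT assay, with a stated time of 72 h; a lower number here means a stronger inhibitor, a higher number a weaker inhibitor:
- compound 1 `CNc1ncnc2c1c(-c1cc3ccccc3o1)cn2[C@@H]1O[C@H](CO)[C@@H](O)[C@H]1O`: 75300 nM
- compound 2 `Cc1ncnc2c1c(-c1ccoc1)cn2[C@@H]1O[C@H](CO)[C@@H](O)[C@H]1O`: 98300 nM
- compound 3 `Cc1ncnc2c1c(-c1cc3ccccc3o1)cn2[C@@H]1O[C@H](CO)[C@@H](O)[C@H]1O`: 84400 nM

Compound 3 lies within the scatter of both compound 1 and compound 2, so its place among them carries little meaning. Compound 4 `Cc1ncnc2c1c(I)cn2[C@@H]1O[C@H](CO)[C@@H](O)[C@H]1O` has iodo in place of 1-benzofuran-2-yl on an aromatic carbon. Within the data shown here, two measured steps bear on this change. The closest is a 1.2-fold lower number from compound 2 to compound 3 (0.07 log units; within the scatter), which swaps the same 1-benzofuran-2-yl group for another ring. The other is a 1.1-fold higher number from compound 1 to compound 3 (0.05 log units; within the scatter), which changes a different group. Among the measured compounds shown here, neither goes beyond the scatter, although no measured step replaces a ring with iodo. The expected change is a 1.4-fold lower number from compound 3 to compound 4 (0.15 log units; within the scatter), so no shift beyond the scatter is anticipated. For compound 4 the estimated value is 60000 nM, with an expected range of 12000 nM to 120000 nM.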

Compound 4, half-maximal inhibitory concentration: 13300 nM
Beside the measured number, compound 4's estimate is 4.5-fold (0.65 log units) above it; measured number inside the range.
By their numbers in this assay, from the lowest: compound 4; then compounds 1, 3 and 2 (each within the scatter of the next).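

In this assay, swapping one ring for another at this position had stayed within the scatter, but losing the ring for a single iodine atom does not: iodo in place of 1-benzofuran-2-yl gives a 6.3-fold lower number from compound 3 to compound 4 (0.80 log units; beyond the scatter), and iodo in place of furan-3-yl gives a 7.4-fold lower number from compound 2 to compound 4 (0.87 log units; beyond the scatter). So the number does respond to this position, and both ring-bearing compounds sit clearly apart from the iodo compound. Nothing available explains this shift. On these data alone, whether bromo, chloro or an amine at this position would give a similar number stays open. So does whether iodo has the same effect on the core of compound 1, which carries methylamino instead of methyl.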